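Swapping Furan Attachment on a Nucleoside-Like Scaffold

This account rests on a few compounds, and the source may have more. Where it says the series, first, only, none or still open, it means among the compounds named here.

Compound 3 `Nc1nc2c(c(-c3ccoc3)cn2[C@@H]2O[C@H](CO)[C@@H](O)[C@H]2O)c(=O)[nH]1` carries a furan-3-yl group on its fused two-ring core. In a functional assay on HepG2 cells (Homo sapiens) for antiproliferative activity, read by XTT assay, with a stated time of 72 h (on this read-out higher numbers stand for weaker inhibition and lower numbers for stronger inhibition), compound 3 gives > 20000 nM, which is a limit of the assay and not a number. Compound 1 `Nc1nc2c(c(-c3ccco3)cn2[C@@H]2O[C@H](CO)[C@@H](O)[C@H]2O)c(=O)[nH]1` differs from compound 3 by furan-2-yl in place of furan-3-yl on an aromatic carbon. In this assay compound 1 gives > 20000 nM, again a limit. The step that the two limits leave unreadable from compound 3 to compound 1 cannot be read because of the limit of > 20000 nM in this assay, at which 3 of the 3 values shown sit. Compound 2 `COc1nc(N)nc2c1c(-c1ccoc1)cn2[C@@H]1O[C@H](CO)[C@@H](O)[C@H]1O` has a different core; how the cores of compound 2 and compound 3 differ is not broken down here. In this assay compound 2 gives > 20000 nM, also a limit. Compound 4 `COc1nc(N)nc2c1c(-c1ccco1)cn2[C@@H]1O[C@H](CO)[C@@H](O)[C@H]1O` is not yet measured and differs from compound 2 by furan-2-yl in place of furan-3-yl on an aromatic carbon, the same change as from compound 3 to compound 1. The step from compound 2 to compound 4 is expected to be a step that the limit leaves unreadable from compound 2 to compound 4, resting on the unreadable step that the two limits leave unreadable from compound 3 to compound 1. For compound 4 the expected value is 30000 nM, most probably again a limit.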

Compound 4, half-maximal inhibitory concentration: > 20000 nM
Compound 4: a limit, no number; the forecaster's own chance of this, stated with the estimate: 85%; the middle value does not contradict the limit.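

No step can be read from compound 2 to compound 4, because both values are limits: the limit of > 20000 nM in this assay, at which 4 of the 4 values shown sit. Going by these compounds, whether furan-2-yl and furan-3-yl differ at all in this assay, on either core, remains open.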